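Swapping the aryl hydrazone end of a thiosemicarbazone

A few compounds are considered here, and "the series" means these few. Any claim that something is new, unique, unknown or untested is made for them only; others in the source may bear on it.

Measured compounds:
- Compound 1, `COc1ccc(/C=N\NC(=S)NC(C)(C)CCC[C@](C)(O)[C@@H]2CC=C(C)CC2)cc1`: 7420 nM
- Compound 2, `CC1=CC[C@@H]([C@@](C)(O)CCCC(C)(C)NC(=S)N/N=C\c2ccc(O)cc2)CC1`: 8870 nM

Both compounds share a thiosemicarbazone core attached to a terpene-derived chain, and both were tested in a functional assay on UACC-62 cells (Homo sapiens) for cytotoxicity, read by sulforhodamine B assay; on this read-out higher numbers stand for weaker inhibition of growth and lower numbers for stronger inhibition of growth. Compound 2 stands nearest compound 1, with a 1.2-fold higher number from compound 1 to compound 2 (0.08 log units; within the scatter), so the two cannot be told apart on this read-out.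

Compound 3, `CC1=CC[C@@H]([C@@](C)(O)CCCC(C)(C)NC(=S)N/N=C(/C)c2ccccc2)CC1`, has not been measured yet. Relative to compound 2 the change is a group of 9 heavy atoms (8 carbon, 1 nitrogen; one six-membered aromatic ring of carbon only) in place of a group of 9 heavy atoms (7 carbon, 1 nitrogen, 1 oxygen; one six-membered aromatic ring of carbon only), on an amide-type nitrogen.

Going by the values given here, only one measured step exists, from compound 1 to compound 2, and it concerns a hydrogen in place of methyl on an oxygen, not the change made here; it was within the scatter. No shown step speaks directly to removing the oxygen and adding a methyl on the imine carbon. The expectation for compound 3 is therefore no step beyond the scatter: a 1.1-fold lower number from compound 2 to compound 3 (0.04 log units; within the scatter). Compound 3 is estimated at 8000 nM, expected to fall between 3000 nM and 22000 nM.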

Compound 3, concentration for 50% growth inhibition: 22400 nM
For compound 3 the middle estimate is 2.8-fold (0.45 log units) below the measured one; the whole stated range lies below it.
By their numbers in this assay, from the lowest: compounds 1 and 2 (each within the scatter of the next); then compound 3.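

In this assay, the swap on the amide-type nitrogen gives a 2.5-fold higher number from compound 2 to compound 3 (0.40 log units; beyond the scatter) and a 3.0-fold higher number from compound 1 to compound 3 (0.48 log units; beyond the scatter), so both steps point to weaker inhibition of growth. This end of the molecule can therefore shift the read-out beyond the scatter, which the step between the two earlier compounds, a 1.2-fold higher number from compound 1 to compound 2 (0.08 log units; within the scatter), did not show. No independent evidence accompanies these numbers to explain the shift.

Each step changes the aromatic oxygen group and the methyl on the imine carbon together, so the compounds shown leave open which of the two accounts for the rise in the number. Also open, going by these compounds, is how this read-out would respond to an amine or a carboxylic acid on the aromatic ring.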